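Adding a Nitrophenoxy Arm to the Side Chain of Compound 3

The compounds below may be only part of what the source reports. "The series", "measured", "known", "first", "only" and "open" are said of these compounds alone.

Measured compounds:
compound 1 `CCOc1cc(=O)n(CCCO)c2c1CC(CC=C(C)C)C(C)(C)C2`, 66.5%
compound 2 `COc1ccccc1NC(=O)Oc1cc(=O)n(CCCO)c2c1CC(CC=C(C)C)C(C)(C)C2`, 71.1%
compound 3 `CCOc1cc(=O)n(CCCO)c2c1CC(C/C=C(\C)CCC=C(C)C)C(C)(C)C2`, 67.8%

All three share one core and were tested in a functional assay on PANC-1 cells (Homo sapiens) for inhibition, read by MTT assay, with a stated time of 24 h, tested at 10 uM; on this read-out higher numbers stand for more inhibition at the one concentration tested (going by the name of the read-out) and lower numbers for less inhibition. Compound 3 stands second highest of the three numbers; compound 1 lies closest to it and compound 2 furthest, yet both gaps fall within the usual scatter, so the three values cannot be told apart.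

Compound 4 `CC(C)=CCC/C(C)=C/CC1Cc2c(OCCCOc3ccc([N+](=O)[O-])cc3)cc(=O)n(CCCO)c2CC1(C)C` has not been measured. It differs from compound 3 by (4-nitrophenoxy)methyl in place of hydrogen on a saturated chain carbon, two bonds along the chain from an oxygen on an aromatic ring.

Two measured steps speak to this change. The step of a number 4.6 percentage points higher from compound 1 to compound 2 (within the scatter) altered the group sitting on the oxygen of the aromatic ring, the same oxygen from which the new chain of compound 4 extends; it stayed within the scatter. The step of a number 1.3 percentage points higher from compound 1 to compound 3 (within the scatter) lengthened the chain elsewhere on the core, again within the scatter. Neither change to a chain or to the group on that oxygen moved this assay beyond its noise, so no step beyond the scatter is expected for compound 4 either.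

Compound 4 is therefore estimated at 69%, between 57% and 81%, an expected step of a number 1.2 percentage points higher from compound 3 to compound 4 (within the scatter).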

Compound 4, a percentage reported as inhibition, at one concentration (the size of the read-out at that concentration, not a potency): 65.1%
Compound 4: middle estimate off by 3.9 percentage points, on the high side, within the range that was stated.
By their numbers in this assay, from the lowest: compounds 4, 1, 3 and 2 (each within the scatter of the next).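

In this assay, putting (4-nitrophenoxy)methyl in place of hydrogen on a saturated chain carbon, two bonds along the chain from an oxygen on an aromatic ring, gives a number 2.7 percentage points lower from compound 3 to compound 4 (within the scatter) and so stays within the scatter. Among the compounds shown here, this is the first look at this carbon: the earlier compounds carry nothing there, and it now appears that a group of 11 heavy atoms with its own six-membered aromatic ring can sit at this place without a change that this read-out can distinguish from noise. No measurement at hand speaks to why the number behaves this way.

Still open is whether the nitro group or the phenoxy ring matters at all, as the compounds shown include no plain phenoxy arm, no amine or carboxylic acid at the end of this chain, and no longer or shorter version of the chain. Also open is whether the same arm would read alike on the core of compound 1, with its 3-methylbut-2-en-1-yl group, and whether any of these compounds would separate at a concentration other than the single one tested.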